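Benzothiophene for fluoroindole on the amide carbonyl

This account rests on a few compounds, and the source may have more. Where it says the series, first, only, none or still open, it means among the compounds named here.

Of the compounds shown here, three sharing one core have been measured in a functional assay on HEK293 cells for antagonist activity at melanin-concentrating hormone receptor 1 (Homo sapiens); a higher number here means a weaker inhibitor, a lower number a stronger inhibitor. Compound 1 `N=C(N)NCCC[C@@H](NC(=O)c1cnc2ccccc2c1)C(=O)NCc1ccc(C(F)(F)F)cc1` gives 96 nM; compound 2 `N=C(N)NCCC[C@@H](NC(=O)c1cc2cc(F)ccc2[nH]1)C(=O)NCc1ccc(C(F)(F)F)cc1` gives 25 nM; compound 3 `N=C(N)NCCC[C@@H](NC(=O)c1ccnc2ccccc12)C(=O)NCc1ccc(C(F)(F)F)cc1` gives 1030 nM. Compound 2 stands at the lowest of the three numbers, with compound 1 nearest and compound 3 furthest, both steps beyond the scatter: a 41-fold higher number from compound 2 to compound 3 (1.61 log units; beyond the scatter).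

Compound 4 `N=C(N)NCCC[C@@H](NC(=O)c1csc2ccccc12)C(=O)NCc1ccc(C(F)(F)F)cc1` is the subject of the next step: 1-benzothiophen-3-yl in place of 5-fluoro-1H-indol-2-yl on a carbonyl carbon. The measured steps that bear on it all change the same aromatic group on the carbonyl carbon. The step of a 3.8-fold lower number from compound 1 to compound 2 (0.58 log units; beyond the scatter) was modest, while an 11-fold higher number from compound 1 to compound 3 (1.03 log units; beyond the scatter) and a 41-fold higher number from compound 2 to compound 3 (1.61 log units; beyond the scatter) were large, so the choice of aromatic group on this carbonyl has moved the number across a wide span. For the measured compounds named here, no measured compound shows the 1-benzothiophen-3-yl group, and none removes the single hydrogen-bond donor of the fluoroindole without also changing ring attachment, so the direction is judged only by analogy. Compound 4 is expected to give a higher number than compound 2, an 8.0-fold higher number from compound 2 to compound 4 (0.90 log units; beyond the scatter), landing near the region of compound 1 rather than compound 3. The estimate for compound 4 is 200 nM, within 50 nM to 1000 nM.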

Compound 4, half-maximal inhibitory concentration: 952 nM
Compound 4: the middle estimate sits 4.8-fold (0.68 log units) below what was measured; low and high end bracket the measured number.
By their numbers in this assay, from the lowest: compound 2; then compound 1; then compounds 4 and 3 (each within the scatter of the next).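

In this assay, the change proves costly, with a 38-fold higher number from compound 2 to compound 4 (1.58 log units; beyond the scatter) even though both groups have one five-membered and one six-membered aromatic ring and differ little in heavy-atom count. Ring count alone therefore does not preserve the value at this carbonyl, and very different aromatic groups can end up at the same level: there is a 1.1-fold lower number from compound 3 to compound 4 (0.03 log units; within the scatter) despite the different ring systems, while a 9.9-fold higher number from compound 1 to compound 4 (1.00 log units; beyond the scatter) places the new group on the weaker side of the quinolin-3-yl group as well. Nothing given here accounts for these steps.

On these data alone, the step from compound 2 to compound 4 changes the ring hetero atom, the point of attachment and the fluorine all at once, so it remains open which of these carries the loss. As far as these compounds go, a 1-benzothiophen-2-yl group or a 1H-indol-2-yl group without the fluorine would separate these changes, and it is also open whether an amine or a carboxylic acid on the 1-benzothiophen-3-yl ring would shift the number in either direction.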